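Aryloxy variation on a piperazine carbamate series

The compounds below may be only part of what the source reports. "The series", "measured", "known", "first", "only" and "open" are said of these compounds alone.

Three members of the series have numbers in an assay on isolated protein for inhibition of Fatty-acid amide hydrolase 1 (Homo sapiens), read by fluorescence; on this read-out lower numbers stand for stronger inhibition and higher numbers for weaker inhibition. Compound 1 `O=C(Oc1ccc([N+](=O)[O-])cc1)N1CCN(S(=O)(=O)c2ccc(Oc3ccccc3)cc2)CC1` gives 322 nM. Compound 2 `O=C(Oc1ccc([N+](=O)[O-])cc1)N1CCN(S(=O)(=O)c2ccc(-c3ccc(Cl)c(Cl)c3)cc2)CC1` gives 382 nM; the step of a 1.2-fold higher number from compound 1 to compound 2 (0.07 log units; within the scatter) does not separate the two. Compound 3 `O=C(Oc1ccc([N+](=O)[O-])cc1)N1CCN(S(=O)(=O)c2ccc(Oc3ccc(Cl)cc3)cc2)CC1` gives 153 nM, the lowest of the three numbers, with a 2.1-fold lower number from compound 1 to compound 3 (0.32 log units; beyond the scatter) and a 2.5-fold lower number from compound 2 to compound 3 (0.40 log units; beyond the scatter) both beyond the scatter but modest in size.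

Compound 4 `O=C(Oc1ccc([N+](=O)[O-])cc1)N1CCN(S(=O)(=O)c2ccc(Oc3ncc(C(F)(F)F)cc3Cl)cc2)CC1` keeps the core of compound 3 and changes the aryloxy part: 3-chloro-5-(trifluoromethyl)pyridin-2-yl in place of 4-chlorophenyl on an oxygen on an aromatic ring. Within the data shown here, no measured pair tests a ring of this kind here. Among the measured compounds shown here, the only step on the same ring, a 2.1-fold lower number from compound 1 to compound 3 (0.32 log units; beyond the scatter), is modest, and the larger exchange a 2.5-fold lower number from compound 2 to compound 3 (0.40 log units; beyond the scatter) is likewise modest; the series so far moves within a narrow band. The expectation for compound 4 in this assay is therefore a step of a 1.1-fold higher number from compound 3 to compound 4 (0.05 log units; within the scatter), with no clear direction beyond the scatter. Compound 4 is expected to give about 170 nM, in a range from 60 nM to 480 nM.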

Compound 4, half-maximal inhibitory concentration: 2950 nM
Compound 4: the middle estimate sits 17-fold (1.24 log units) below what was measured, and the stated range ends below it.
By their numbers in this assay, from the lowest: compound 3; then compounds 1 and 2 (each within the scatter of the next); then compound 4.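

In this assay, among these compounds, the group on the oxygen on an aromatic ring can move the number well outside the earlier narrow band: 3-chloro-5-(trifluoromethyl)pyridin-2-yl in place of 4-chlorophenyl gives a 19-fold higher number from compound 3 to compound 4 (1.29 log units; beyond the scatter) and is the only large step. The same exchange stands out against the other two compounds as well, with a 9.2-fold higher number from compound 1 to compound 4 (0.96 log units; beyond the scatter) and a 7.7-fold higher number from compound 2 to compound 4 (0.89 log units; beyond the scatter) both beyond the scatter, so the rise does not rest on compound 3 alone as the reference. No measured evidence shown here bears on this result.

The exchange brings in the ring nitrogen and the trifluoromethyl group together and alters the chloro substitution, so the step cannot be assigned to any one of these changes. On these data alone, how a plain pyridin-2-yl, or a phenyl carrying only trifluoromethyl, would read on the same oxygen remains open.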